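Vero cell tolerance across a hydrazine-substituted piperazine series

The source may hold more compounds than are shown below. What is called first, only, known or untested is meant among the compounds shown, and "the series" means these compounds.

Compound 1 `O=c1nc(N2CCN(NCC3CCCC3)CC2)sc2c([N+](=O)[O-])cc(C(F)(F)F)cc12` in an ADME assay on Vero cells (Chlorocebus sabaeus) for cytotoxicity, read by MTT assay, with a stated time of 72 h (a higher number here means that more compound is tolerated, a lower number that less compound is tolerated), gives > 64 ug/mL, which is a limit of the assay and not a number. Compound 2 `CC(C)CN(CC(C)C)N1CCN(c2nc(=O)c3cc(C(F)(F)F)cc([N+](=O)[O-])c3s2)CC1` gives > 64 ug/mL in this assay, again a limit. The step that the two limits leave unreadable from compound 1 to compound 2 is unreadable because of the limit of > 64 ug/mL in this assay, at which 2 of the 2 values shown sit. For the measured compounds named here, compound 2 thus stands at the limit, as do all values so far. Compound 3 `Cc1cccc(F)c1CNN1CCN(c2nc(=O)c3cc(C(F)(F)F)cc([N+](=O)[O-])c3s2)CC1` differs from compound 2 by (2-fluoro-6-methylbenzyl)amino in place of diisobutylamino on an amine nitrogen in a ring. Going by the values given here, no measured step bears readably on this change. The expected step of a number no higher from compound 2 to compound 3 (the limit leaves the size open) is none beyond the scatter. Compound 3 is therefore estimated at 64 ug/mL, with a range from 32 ug/mL to 128 ug/mL, most likely reported as a limit once more.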

Compound 3, half-maximal cytotoxic concentration: > 64 ug/mL
Compound 3: no number, only a limit; the forecaster's own chance of this, stated with the estimate: 75%; the middle value sits exactly at the limit.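

No step can be read among compound 1, compound 2 and compound 3, because all three values are the same assay limit and not numbers: the limit of > 64 ug/mL in this assay, at which 3 of the 3 values shown sit.

The compounds shown leave open whether the groups on the ring amine nitrogen differ at all in this assay.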